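This account rests on a few compounds, and the source may have more. Where it says the series, first, only, none or still open, it means among the compounds named here.

In a functional assay on K562 cells (Homo sapiens) for cytotoxicity, read by trypan blue exclusion, with a stated time of 96 h (a lower number here means a stronger inhibitor, a higher number a weaker inhibitor), three compounds sharing one core have been measured. Compound 1 (`COc1cc(OC)c(/C=C/S(=O)(=O)Cc2ccc(F)c(N)c2)c(OC)c1`) gives 2500 nM, compound 3 (`COc1cc(OC)c(/C=C/S(=O)(=O)Cc2ccc(Br)c(N)c2)c(OC)c1`) gives 750 nM, and compound 2 (`COc1cc(OC)c(/C=C/S(=O)(=O)Cc2ccc(OC)c(N)c2)c(OC)c1`) gives 2.5 nM. Compound 2 has the lowest number of the three, and its steps to the other two lie beyond the scatter: a 1000-fold lower number from compound 1 to compound 2 (3.00 log units; beyond the scatter) and a 300-fold higher number from compound 2 to compound 3 (2.48 log units; beyond the scatter). The remaining step, a 3.3-fold lower number from compound 1 to compound 3 (0.52 log units; beyond the scatter), is modest.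

Compound 4 (`COC(=O)C(F)(F)Nc1cc(CS(=O)(=O)/C=C/c2c(OC)cc(OC)cc2OC)ccc1OC`) alters compound 2 at its amino group: difluoro(methoxycarbonyl)methyl in place of hydrogen on a nitrogen on an aromatic ring, with difluoro(methoxycarbonyl)methyl in place of hydrogen on a nitrogen on an aromatic ring. Within the data shown here, none of the measured steps touches that nitrogen, since all three swap groups on an aromatic carbon. Among the measured compounds shown here, they give no direct size for this change and show only that one swap in this set can produce a large step. Starting from the 2.5 nM of compound 2, a higher number is expected, of moderate size and with wide uncertainty. The expected change is a 12-fold higher number from compound 2 to compound 4 (1.08 log units; beyond the scatter). For compound 4 the estimate is 30 nM, with an expected range of 3 nM to 400 nM.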

Compound 4, half-maximal inhibitory concentration: 250 nM
For compound 4 the middle estimate is 8.3-fold (0.92 log units) below the measured one, and the stated range covers the measured number.
By their numbers in this assay, from the lowest: compound 2; then compound 4; then compound 3; then compound 1.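

Until this point, every step in this assay had swapped a group on an aromatic carbon; here the change falls on the nitrogen on an aromatic ring, and it gives a 100-fold higher number from compound 2 to compound 4 (2.00 log units; beyond the scatter) with the methoxy of compound 2 kept in place. The nitrogen is therefore a second place in this set where one change produces a large step, and it does so in the compound with the lowest number. Nothing available here accounts for the size of this step.

The compounds shown leave open whether the step follows from losing the hydrogen on that nitrogen or from the whole difluoro(methoxycarbonyl)methyl group. A methyl or an acetyl on the same nitrogen would separate the two, and the same group on the bromo compound 3 would show whether the step carries over.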